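Fluoropyridinyl Arylpiperazine Variant: Expected Alpha-1 Affinity

This account rests on a few compounds, and the source may have more. Where it says the series, first, only, none or still open, it means among the compounds named here.

compound 1 `CNc1ccccc1N1CCN(CCCCn2ncc(=O)n(C)c2=O)CC1`: 450 nM
compound 2 `Cn1c(=O)cnn(CCCCN2CCN(c3ccccc3F)CC2)c1=O`: 9.73 nM
compound 3 `Cn1c(=O)cnn(CCCCN2CCN(c3ccccn3)CC2)c1=O`: 262 nM

Three measured compounds share a common core and differ only in the aromatic group on the ring amine nitrogen. In an assay for displacement of a labelled ligand from Adrenergic receptor alpha-1 (Homo sapiens) (on this read-out lower numbers stand for stronger inhibition and higher numbers for weaker inhibition), compound 1 gives 450 nM, the highest of the three numbers. Compound 3 gives 262 nM, which is within the scatter of compound 1. Compound 2 gives 9.73 nM, far below both.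

Compound 4 `Cn1c(=O)cnn(CCCCN2CCN(c3ccc(F)cn3)CC2)c1=O` has not been measured in this assay. It differs from compound 1 by 5-fluoropyridin-2-yl in place of 2-(methylamino)phenyl on an amine nitrogen in a ring.

Within the data shown here, two measured steps bear on this change. The closest is a 1.7-fold lower number from compound 1 to compound 3 (0.23 log units; within the scatter), which also replaces the 2-(methylamino)phenyl with a pyridin-2-yl and made no difference beyond the scatter. The other is a 46-fold lower number from compound 1 to compound 2 (1.67 log units; beyond the scatter), where fluorine in place of methylamino brought a large drop, and likewise a 27-fold higher number from compound 2 to compound 3 (1.43 log units; beyond the scatter) in reverse. Among the measured compounds shown here, no measured pair isolates the effect of a fluorine on the pyridine, so the expectation leans on the pyridin-2-yl step with a modest allowance for the fluorine.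

The expected step is therefore a 3.0-fold lower number from compound 1 to compound 4 (0.48 log units; beyond the scatter). Compound 4 is expected to give about 150 nM, with a range from 40 nM to 600 nM.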

Compound 4, inhibition constant: > 10000 nM
Compound 4 gave a limit, no number (the forecaster's own chance of this, stated with the estimate: 2%); middle value at least 66-fold (1.82 log units) from the limit.
By their numbers in this assay, from the lowest: compound 2; then compounds 3 and 1 (each within the scatter of the next). At a limit, above all of these: compound 4.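

In this assay, compound 4 gives a limit and not a number: the limit of > 10000 nM in this assay, at which 1 of the 4 values shown sits. Among these compounds, its only difference from the pyridin-2-yl group of compound 3 is fluoro in place of hydrogen on an aromatic carbon, yet this single change gives an at least 38-fold higher number from compound 3 to compound 4 (1.58 log units; beyond the scatter), a large step that the earlier compounds gave no sign of, since their only fluoro sits on the 2-fluorophenyl group of compound 2. The same place on the ring amine nitrogen now also shows an at least 22-fold higher number from compound 1 to compound 4 (1.34 log units; beyond the scatter), although the plain pyridin-2-yl group had stayed within the scatter of the 2-(methylamino)phenyl group, and an at least 1000-fold higher number from compound 2 to compound 4 (3.01 log units; beyond the scatter), so a fluoro on the aromatic group goes with the lowest number in compound 2 and with the limit in compound 4.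

The compounds shown leave open whether this loss belongs to fluoro itself or to any substituent at that carbon of the pyridin-2-yl group, which a chloro, a methyl or a methoxy group there would help to separate. They also leave open whether a fluoro on a different carbon of that ring would give the same result.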